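The source may report more compounds than this note shows. Statements on the series, on what has been measured and on what is new or still open speak of the compounds shown alone.

Working notes on the series. Among the measured compounds shown here, compound 2 `CC(=O)OC[C@H]1O[C@@H](n2cc(CN3C(=O)/C(=C\c4ccc(N(C)C)cc4)c4ccccc43)nn2)[C@H](OC(C)=O)[C@@H](OC(C)=O)[C@@H]1OC(C)=O` is measured in a functional assay on DU-145 cells (Homo sapiens) for cytotoxicity, read by sulforhodamine B assay, with a stated time of 48 h (a lower number here means a stronger inhibitor, a higher number a weaker inhibitor), at 10100 nM; compound 1 `CC(=O)OC[C@H]1O[C@@H](n2cc(CN3C(=O)/C(=C\c4ccc(C)cc4)c4ccccc43)nn2)[C@H](OC(C)=O)[C@@H](OC(C)=O)[C@@H]1OC(C)=O` in this assay gives 9400 nM, and the two lie within the scatter of each other, so compound 2 stands level with its only neighbour. For the measured compounds named here, the one measured step, a 1.1-fold higher number from compound 1 to compound 2 (0.03 log units; within the scatter), bears on the arylidene part that changes again here. Compound 3 `CC(=O)OC[C@H]1O[C@@H](n2cc(CN3C(=O)/C(=C\c4ccco4)c4ccccc43)nn2)[C@H](OC(C)=O)[C@@H](OC(C)=O)[C@@H]1OC(C)=O` carries the change (furan-2-yl in place of 4-(dimethylamino)phenyl on a double-bonded chain carbon bound to a double-bonded ring carbon). Since the earlier swap at this position left the number essentially unchanged, no step beyond the scatter is expected, a 1.0-fold lower number from compound 2 to compound 3 (0.00 log units; within the scatter). Compound 3 is estimated at 10000 nM, in the range 4000 nM to 25000 nM.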

Compound 3, half-maximal inhibitory concentration: 16900 nM
Compound 3: the middle estimate sits 1.7-fold (0.23 log units) below what was measured; the measured number falls inside the stated range.
By their numbers in this assay, from the lowest: compounds 1, 2 and 3 (each within the scatter of the next).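

In this assay, furan-2-yl in place of 4-(dimethylamino)phenyl gives a 1.7-fold higher number from compound 2 to compound 3 (0.22 log units; within the scatter), and furan-2-yl in place of 4-methylphenyl gives a 1.8-fold higher number from compound 1 to compound 3 (0.25 log units; within the scatter). Compounds 1 and 2 differed only in the group on a six-membered aromatic ring of carbon only, whereas compound 3 shows that replacing that whole ring with a five-membered aromatic ring with 1 hetero atom also stays within the scatter. No measurement at hand accounts for this result.

As far as these compounds go, it remains open whether any group at this place moves the number beyond the scatter. A carboxylic acid or a longer chain on this double-bonded chain carbon would test that.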